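The source may hold more compounds than are shown below. What is called first, only, known or untested is meant among the compounds shown, and "the series" means these compounds.

In a functional assay on HL-60 cells (Homo sapiens) for cytotoxicity, read by WST assay, with a stated time of 48 h (on this read-out higher numbers stand for weaker inhibition and lower numbers for stronger inhibition), compound 2 `COc1cc(C(c2ccc(O)c(OC)c2)[C@H](C)C(C)C)ccc1O` gives 17000 nM, the highest of the two numbers measured here. For the measured compounds named here, compound 3 `CCCCCCCC[C@H](C(C)C)C(c1ccc(O)c(OC)c1)c1ccc(O)c(OC)c1` gives 3700 nM, and the step of a 4.6-fold lower number from compound 2 to compound 3 (0.66 log units; beyond the scatter) is the only single-group change measured. Compound 1 `COc1ccc(C(c2ccc(OC)c(OC)c2)[C@H](C)[C@H](C)CO)cc1OC` is reported only as a limit, > 100000 nM, which is the limit of > 100000 nM in this assay, at which 1 of the 3 values shown sits. Compound 4 `COc1cc(C(c2ccc(O)c(OC)c2)[C@@H](C)[C@@H](C)CF)ccc1O` differs from compound 2 in one place: 2-(fluoromethyl)-1-methylpropyl in place of 1,2-dimethylpropyl on a saturated chain carbon bound to two aromatic carbons. Going by the values given here, no measured step tests this exchange of one saturated group for another carrying a fluorine; the one known step came from adding a heptyl group and was modest. A change of similar or smaller size is expected here. Compound 4 is therefore expected to give 25000 nM, with a likely range from 8000 nM to 80000 nM. That expectation corresponds to a step of a 1.5-fold higher number from compound 2 to compound 4 (0.17 log units; within the scatter).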

Compound 4, half-maximal inhibitory concentration: 38000 nM
For compound 4 the middle estimate is 1.5-fold (0.18 log units) below the measured one; measured number inside the range.
By their numbers in this assay, from the lowest: compound 3; then compound 2; then compound 4. At a limit, above all of these: compound 1.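

Replacing 1,2-dimethylpropyl with 2-(fluoromethyl)-1-methylpropyl on a saturated chain carbon bound to two aromatic carbons gives a 2.2-fold higher number from compound 2 to compound 4 (0.35 log units; beyond the scatter), showing that a change here can also weaken the read-out, whereas adding heptyl gave a 4.6-fold lower number from compound 2 to compound 3 (0.66 log units; beyond the scatter). The entering group brings both a fluorine and a second defined stereocentre, and this single step cannot separate the two. Nothing measured here explains the shift. Going by these compounds, whether an amine or a carboxylic acid in place of the fluorine would raise or lower the number remains open.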